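The source may report more compounds than this note shows. Statements on the series, on what has been measured and on what is new or still open speak of the compounds shown alone.

Measured compounds in a functional assay on MDA-MB-231 cells (Homo sapiens) for antiproliferative activity, read by WST assay, with a stated time of 72 h; on this read-out higher numbers stand for weaker inhibition and lower numbers for stronger inhibition:

compound 1 `Cn1c(SCC#CCN2CCCC2)nc2nc(Cl)nc(SCC#CCN3CCCC3)c21`: 3830 nM
compound 2 `Cn1cnc2nc(SCC#CCN3CCCCC3)nc(SCC#CCN3CCCCC3)c21`: 7350 nM
compound 3 `CCN(CC)CC#CCSc1nc2c(c(=O)[nH]c(=O)n2C)n1C`: 68100 nM

Compound 3 stands highest of the three numbers in this assay, its value lying beyond the scatter from both others: the nearest is compound 2, the furthest compound 1. Within the data shown here, compound 1 and compound 2 differ from compound 3 in the core and in the number of chains, so no single step among the measured compounds isolates one change, and nothing in the measured set speaks directly to the amine at the end of the chain.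

Compound 4 `Cn1c(SCC#CCN2CCCC2)nc2c1c(=O)[nH]c(=O)n2C` is not yet measured in this assay. It differs from compound 3 in one place: pyrrolidin-1-yl in place of diethylamino on a saturated chain carbon bound to a triple-bonded carbon. The rest of compound 3, core and chain, is kept unchanged.

Among the measured compounds shown here, with no measured pair that shows this exchange on its own, the expected step from compound 3 to compound 4 is a 1.2-fold lower number from compound 3 to compound 4 (0.09 log units; within the scatter), that is, no change beyond the scatter in either direction. For the measured compounds named here, compound 4 is therefore estimated at 55000 nM in this assay, with a range from 20000 nM to 150000 nM, since compound 3 gives 68100 nM and no measured step argues for a move away from it.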

Compound 4, half-maximal inhibitory concentration: 472000 nM
The estimate for compound 4 lay 8.6-fold (0.93 log units) below the measured number; measured number above the stated range.
By their numbers in this assay, from the lowest: compounds 1 and 2 (each within the scatter of the next); then compound 3; then compound 4.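

In this assay, the amine at the end of the chain proves to be a position that responds on its own: with core and chain held fixed, pyrrolidin-1-yl in place of diethylamino gives a 6.9-fold higher number from compound 3 to compound 4 (0.84 log units; beyond the scatter), a step beyond the scatter. The two groups match in heavy-atom count, in carbon and nitrogen content, and in hydrogen-bond donor and acceptor counts, and the printed difference between them is the five-membered non-aromatic ring, so these counts alone do not set the value at this position. Nothing measured here explains the size or direction of this step.

This single pair gives no trend across amines, and dimethylamino, morpholine or a longer chain between the triple bond and the amine could each fall on either side of compound 3 on this core. Whether the same exchange gives a step of similar size and direction on the cores of compound 1 and compound 2, which carry two chains, also remains open, as no pair shown isolates it there.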